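Cytotoxicity across the shared core: oxolane to pyrrolidine

The source may report more compounds than this note shows. Statements on the series, on what has been measured and on what is new or still open speak of the compounds shown alone.

Compound 2 `c1ccc(-c2nc3ccccn3c2NC2CCOC2)nc1` stands in an ADME assay on THP-1 cells (Homo sapiens) for cytotoxicity (a lower number here means that less compound is tolerated, a higher number that more compound is tolerated), at a limit, > 50000 nM. Compound 1 `CN(C)CCNc1c(-c2ccccn2)nc2ccccn12` likewise gives only a limit, > 50000 nM. The step that the two limits leave unreadable from compound 1 to compound 2 therefore shows no readable size; both values sit at the limit of > 50000 nM in this assay, at which 2 of the 2 values shown sit. Compound 3 `c1ccc(-c2nc3ccccn3c2NC2CCNC2)nc1` differs from compound 2 by pyrrolidin-3-yl in place of oxolan-3-yl on a nitrogen on an aromatic ring. Going by the values given here, the single measured step bears on this change only by showing that both ends sit at the limit, so no step beyond the scatter is expected, and the expected step of a number no higher from compound 2 to compound 3 (the limit leaves the size open) is estimated as flat. Compound 3 is expected at 50000 nM, estimated between 25000 nM and 100000 nM, most likely again reported only as a limit.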

Compound 3, half-maximal cytotoxic concentration: > 50000 nM
Compound 3: no number, only a limit; the forecaster's own chance of this, stated with the estimate: 80%; the middle value lies on the limit itself.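

Going by these compounds alone, compound 3 joins compound 1 and compound 2 at a limit in this assay, so no new step among them can be read: the limit of > 50000 nM in this assay, at which 3 of the 3 values shown sit. The compounds shown leave open whether any change on the shared core gives a readable cytotoxic concentration.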